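Replacing the piperazine of compound 1 with a thiadiazolylsulfanyl group

This account rests on a few compounds, and the source may have more. Where it says the series, first, only, none or still open, it means among the compounds named here.

Compound 1 `CCN1CCN(c2cc(C(F)(F)F)nc(SCc3ccc(C(F)(F)F)cc3)n2)CC1` gives 25600 nM
Compound 2 `CC(C)(C)OC(=O)N1CCN(c2cc(C(F)(F)F)nc(SCc3ccc(C(F)(F)F)cc3)n2)CC1` gives 22200 nM
Compound 3 `FC(F)(F)c1ccc(CSc2nc(Sc3nnnn3-c3ccccc3)cc(C(F)(F)F)n2)cc1` gives 12400 nM

In a functional assay on MGC-803 cells (Homo sapiens) for inhibition, read by MTT assay, with a stated time of 72 h (on this read-out higher numbers stand for weaker inhibition and lower numbers for stronger inhibition), compound 1 gives 25600 nM as its number, which stands level with compound 2 within the scatter and above compound 3. Compound 4 `Cc1nnc(Sc2cc(C(F)(F)F)nc(SCc3ccc(C(F)(F)F)cc3)n2)s1` differs from compound 1 by one change, ((5-methyl-1,3,4-thiadiazol-2-yl)sulfanyl in place of 4-ethylpiperazin-1-yl on an aromatic carbon), on an aromatic carbon. For the measured compounds named here, the only measured step, a 1.2-fold lower number from compound 1 to compound 2 (0.06 log units; within the scatter), altered just the group on the amine nitrogen and does not cover this exchange. The nearest guide is compound 3 at 12400 nM in this assay, which also carries a sulfur-linked aromatic ring at that place. The estimated change is a 2.0-fold lower number from compound 1 to compound 4 (0.29 log units; within the scatter), a modest expected move toward stronger inhibition. Compound 4 is expected at 13000 nM, with an estimated range from 5500 nM to 30000 nM in this assay.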

Compound 4, half-maximal inhibitory concentration: 11400 nM
Compound 4: middle estimate off by 1.1-fold (0.06 log units), on the high side, and the stated range covers the measured number.
By their numbers in this assay, from the lowest: compounds 4, 3, 2 and 1 (each within the scatter of the next, the first and the last beyond it).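

In this assay, (5-methyl-1,3,4-thiadiazol-2-yl)sulfanyl in place of 4-ethylpiperazin-1-yl gives a 2.2-fold lower number from compound 1 to compound 4 (0.35 log units; beyond the scatter), a modest step beyond the scatter, which the change on the amine nitrogen had not given. With 5-methyl-1,3,4-thiadiazol-2-yl in place of 1-phenyl-1H-tetrazol-5-yl on the sulfur, the step is a 1.1-fold lower number from compound 3 to compound 4 (0.04 log units; within the scatter), so these two sulfur-linked rings stand level here. No available evidence explains either step.

Still open, on these data alone, is what a longer chain in place of the methyl on the thiadiazole of compound 4 would give. So is what an amine on that ring, or an oxygen link in place of the sulfur, would give.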